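From 4-methoxybenzyl to 4-fluorobenzyl on sulfur

A few compounds are considered here, and "the series" means these few. Any claim that something is new, unique, unknown or untested is made for them only; others in the source may bear on it.

In a functional assay on PC-3 cells (Homo sapiens) for inhibition, read by MTT assay, with a stated time of 48 h (a lower number here means a stronger inhibitor, a higher number a weaker inhibitor), compound 1 `COc1cc(-c2nnc(S)n2-c2ccc(N(C)C)cc2)cc(OC)c1OC` gives > 60000 nM, which is a limit and not a number. Compound 2 `COc1ccc(CSc2nnc(-c3cc(OC)c(OC)c(OC)c3)n2-c2ccc(N(C)C)cc2)cc1` gives > 60000 nM in this assay, again a limit and not a number. Compound 2 therefore has no measured number, and the series stands at the limit of > 60000 nM in this assay, at which 2 of the 2 values shown sit.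

Compound 3 `COc1cc(-c2nnc(SCc3ccc(F)cc3)n2-c2ccc(N(C)C)cc2)cc(OC)c1OC` carries fluoro in place of methoxy on an aromatic carbon, para to a large group, so that 4-methoxybenzyl becomes 4-fluorobenzyl: fluoro in place of methoxy on an aromatic carbon.

Going by the values given here, the one measured step that bears on this change is a step that the two limits leave unreadable from compound 1 to compound 2, with 4-methoxybenzyl in place of hydrogen on a sulfur. Among the compounds with values here, it involves the same benzyl position but offers no size to carry over, and no measured step covers the exchange of methoxy for fluoro. No step beyond the scatter is therefore expected in this assay, and a further limit is the likeliest report for compound 3.

The expected change is a number no higher from compound 2 to compound 3 (the limit leaves the size open).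

For compound 3 the estimated value is 60000 nM, with an expected range of 25000 nM to 120000 nM.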

Compound 3, half-maximal inhibitory concentration: 46500 nM
Compound 3: the middle estimate sits 1.3-fold (0.11 log units) above what was measured; low and high end bracket the measured number.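

In this assay, going by these compounds alone, compound 3 gives 46500 nM as the first number of the series and not a limit, so 4-fluorobenzyl on sulfur is the first group here with a readable value. Fluoro in place of methoxy on an aromatic carbon gives an at least 1.2-fold lower number from compound 2 to compound 3 (0.11 log units; that floor lies within the scatter) and 4-fluorobenzyl in place of hydrogen on a sulfur gives an at least 1.2-fold lower number from compound 1 to compound 3 (0.11 log units; that floor lies within the scatter) as its companion reading; both are floors set against limits, so neither shows a change beyond the scatter. The step from compound 1 to compound 2 cannot be read, and the series still rests largely on one limit: the limit of > 60000 nM in this assay, at which 2 of the 3 values shown sit.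

The compounds shown leave open whether any group on this sulfur can give a number clearly beyond the scatter, since they cover only hydrogen, 4-methoxybenzyl and 4-fluorobenzyl. Chloro or a carboxylic acid in the place of fluoro, or an amine at the end of a longer chain on sulfur in place of the benzyl group, would test how far this position can move the number.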